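The source may hold more compounds than are shown below. What is called first, only, known or untested is meant among the compounds shown, and "the series" means these compounds.

Within the data shown here, in an assay on isolated protein for inhibition of Rho-associated protein kinase 1 (Homo sapiens), read by scintillation counting, radiometric assay and 33P incorporation, with a stated time of 40 min, in the presence of a further agent that is not named here (a higher number here means a weaker inhibitor, a lower number a stronger inhibitor), compound 3 `O=C(COc1ccc2c(=O)ccoc2c1)Nc1cccc(NC(=O)c2ccccc2)c1` gives 120 nM, one of only two numbers in hand, and compound 1 `CN(C)c1ccc(C(=O)Nc2cccc(NC(=O)COc3ccc4c(c3)OCCC4=O)c2)cc1` at 144 nM sits within the scatter of it. Compound 2 `CN(C)c1ccc(C(=O)Nc2cccc(NC(=O)COc3ccc4occc(=O)c4c3)c2)cc1` reaches only the limit > 10000 nM in this assay. Among the measured compounds shown here, the single step measured in one place, an at least 69-fold higher number from compound 1 to compound 2 (1.84 log units; beyond the scatter), changes the group on the oxygen on a saturated carbon, and the limit of > 10000 nM in this assay, at which 1 of the 3 values shown sits, shows it ending at a limit; it says nothing about the ring where compound 4 `COc1ccc(C(=O)Nc2cccc(NC(=O)COc3ccc4c(=O)ccoc4c3)c2)cc1` differs from compound 3 by methoxy in place of hydrogen on an aromatic carbon. For the measured compounds named here, no measured step bears on this change, so the expected step of no change at the digits printed from compound 3 to compound 4 (within the scatter) lies within the scatter. Compound 4 is therefore estimated at 120 nM, between 45 nM and 320 nM.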

Compound 4, half-maximal inhibitory concentration: 18 nM
For compound 4 the middle estimate is 6.7-fold (0.82 log units) above the measured one; measured number outside the range, below it.
By their numbers in this assay, from the lowest: compound 4; then compounds 3 and 1 (each within the scatter of the next). At a limit, above all of these: compound 2.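

Methoxy in place of hydrogen on an aromatic carbon, para to a large group, gives a 6.7-fold lower number from compound 3 to compound 4 (0.82 log units; beyond the scatter) in this assay and is the first measured change at this position. It shows that this carbon of the phenyl ring can carry a substituent and that the number then falls. Nothing in the evidence at hand accounts for this step.

Open, on these data alone, is whether a hydroxyl, a fluorine or an ethoxy group at this place would do the same. Also open, as far as these compounds go, is whether methoxy on another carbon of that ring would.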